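A few compounds are considered here, and "the series" means these few. Any claim that something is new, unique, unknown or untested is made for them only; others in the source may bear on it.

Measured compounds in an ADME assay on MT4 cells (Homo sapiens) for cytotoxicity, read by MTT assay, with a stated time of 96 h; a lower number here means that less compound is tolerated, a higher number that more compound is tolerated:
- compound 1, `CN1CCN(CC(=O)Nc2ccc(-c3nc4cc(Cl)c(Cl)cc4[nH]3)cc2)CC1`: 11000 nM
- compound 2, `C#C[C@@]1(O)[C@H](O)[C@@H](CO)O[C@H]1n1ccc(N)nc1=O`: >= 100000 nM, which is a limit of the assay rather than a number

Going by the values given here, compound 1 stands as the only compound with a measured number in this assay; the other value is the limit of >= 100000 nM in this assay, at which 1 of the 2 values shown sits, and so gives no point of comparison. Among the compounds with values here, no pair of measured compounds differs in a single place, so no measured step is available to guide the change to compound 3, `CC(=O)Nc1ccc(-c2nc3cc(Cl)c(Cl)cc3[nH]2)cc1`. Compound 3 differs from compound 1 by hydrogen in place of 4-methylpiperazin-1-yl on a saturated chain carbon bound to a carbonyl carbon. Within the data shown here, with no measured step to lean on, the expected step in this assay is none beyond the usual scatter, with a slight lean toward less compound being tolerated. The expected step from compound 1 to compound 3 is therefore a 1.4-fold lower number from compound 1 to compound 3 (0.14 log units; within the scatter). Compound 3 is estimated at 8000 nM in this assay, within a range from 2500 nM to 30000 nM.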

Compound 3, half-maximal cytotoxic concentration: > 100000 nM
Compound 3: a limit, no number; the forecaster's own chance of this, stated with the estimate: 15%; middle value at least 12-fold (1.09 log units) away from the limit.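

In this assay, replacing the 4-methylpiperazin-1-yl with hydrogen on a saturated chain carbon bound to a carbonyl carbon gives an at least 9.0-fold higher number from compound 1 to compound 3 (0.95 log units; beyond the scatter). Going by these compounds alone, this single step is the first measured evidence at this position, and it ties the lower number of compound 1 to the presence of the 4-methylpiperazin-1-yl, with the shared core left unchanged. Compound 3 sits at a limit of the assay rather than at a number: the limit of > 100000 nM in this assay, at which 1 of the 3 values shown sits.

Going by these compounds, the full size of the step therefore stays open, as a limit gives no end point. Also open, on these data alone, is whether a smaller amine such as dimethylamino, a morpholine ring or a carboxylic acid on the same carbon would give a number nearer to compound 1 or to compound 3.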